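Replacing cyclopropyl with pyridin-2-yl on an amiloride-like core

The source may report more compounds than this note shows. Statements on the series, on what has been measured and on what is new or still open speak of the compounds shown alone.

Of the compounds shown here, two sharing one core have been measured in an assay for inhibition of acid-sensing ion channel 3 (Homo sapiens), read by patch clamp, tested at 20 uM; a lower number here means less inhibition, a higher number more inhibition at the concentration tested (going by the name of the read-out). Compound 1, `NC(N)=NC(=O)c1nc(Cl)c(NCc2cccc(F)c2)nc1N`, carries a (3-fluorophenyl)methyl group on one of its ring nitrogens; in this assay compound 1 gives 90%. Compound 2, `NC(N)=NC(=O)c1nc(Cl)c(NC2CC2)nc1N`, carries cyclopropyl at the same nitrogen, and in this assay compound 2 gives 78%. Among the two numbers compound 2 stands lowest, and the gap to compound 1 lies beyond the usual scatter of repeated measurements.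

Compound 3, `NC(N)=NC(=O)c1nc(Cl)c(Nc2ccccn2)nc1N`, has not yet been measured. It differs from compound 2 in one place: pyridin-2-yl in place of cyclopropyl on a nitrogen on an aromatic ring. Among the measured compounds shown here, no measured pair shows this exact change, so its effect can only be guessed from the two numbers at hand, which show that the group on this nitrogen can shift the read-out while the rest of the core is unchanged.

The expectation is a small step upward from compound 2, not clearly beyond the scatter, a number 4 percentage points higher from compound 2 to compound 3 (within the scatter). For compound 3 the estimated inhibition in this assay is 82%, with a likely range from 62% to 95%.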

Compound 3, a percentage reported as inhibition, at one concentration (the size of the read-out at that concentration, not a potency): 25%
Compound 3: middle estimate off by 57 percentage points, on the high side; the whole stated range lies above it.
By their numbers in this assay, from the lowest: compound 3; then compound 2; then compound 1.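

In this assay, the group on this nitrogen can do far more than the first two compounds suggested: with the rest of the core unchanged, pyridin-2-yl in place of cyclopropyl gives a number 53 percentage points lower from compound 2 to compound 3 (beyond the scatter). Compound 1 also carries an aromatic ring in its (3-fluorophenyl)methyl group, yet gives 90%, so having an aromatic ring in the group on this nitrogen does not by itself go with a low number. The data shown offer no measurement that explains the drop.

The compounds shown leave open whether the low number in compound 3 goes with the nitrogen inside the pyridine ring or with the aromatic ring sitting on the nitrogen without a linking carbon. Phenyl on this nitrogen would test the first possibility, pyridin-2-ylmethyl would test the second, and a small open chain such as ethyl would show whether cyclopropyl itself matters for the higher number of compound 2.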